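Swapping Pyrrolidin-1-yl for Cyclopentylmethoxy on the Shared Core

This account rests on a few compounds, and the source may have more. Where it says the series, first, only, none or still open, it means among the compounds named here.

Compound 1 `O=C(NCc1ccc(C(F)(F)F)nc1N1CCCCC1)Nc1cccc2[nH]c(=O)ccc12` gives 0.75 nM in an assay on HEK cells for antagonist activity at transient receptor potential cation channel subfamily V member 1 (Homo sapiens), read by FLIPR (on this read-out higher numbers stand for weaker inhibition and lower numbers for stronger inhibition), and compound 2 `O=C(NCc1ccc(C(F)(F)F)nc1N1CCCC1)Nc1cccc2[nH]c(=O)ccc12` gives 0.94 nM in this assay. Going by the values given here, the single measured step, a 1.3-fold higher number from compound 1 to compound 2 (0.10 log units; within the scatter), left the number essentially unchanged, so compound 2 sits alongside compound 1 within the scatter. Compound 3 `O=C(NCc1ccc(C(F)(F)F)nc1OCC1CCCC1)Nc1cccc2[nH]c(=O)ccc12` differs from compound 2 by cyclopentylmethoxy in place of pyrrolidin-1-yl on an aromatic carbon. Among the compounds with values here, no measured step covers an ether at this place, and the one ring-size step was small. The expected step of a 2.1-fold higher number from compound 2 to compound 3 (0.33 log units; beyond the scatter) is therefore modest, leaning toward weaker inhibition. Compound 3 is estimated at 2 nM, within a range from 0.5 nM to 8 nM.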

Compound 3, half-maximal inhibitory concentration: 2.18 nM
Estimate against measurement, compound 3: 1.1-fold (0.04 log units) below; the range from low to high includes it.
By their numbers in this assay, from the lowest: compounds 1 and 2 (each within the scatter of the next); then compound 3.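

In this assay, going by these compounds alone, the ether is the first change at this place to go beyond the scatter, with a 2.3-fold higher number from compound 2 to compound 3 (0.37 log units; beyond the scatter) and a 2.9-fold higher number from compound 1 to compound 3 (0.46 log units; beyond the scatter) both modest. Replacing either ring amine with cyclopentylmethoxy therefore costs some inhibition, but only a limited amount. No measurement here accounts for this difference. The compounds shown do not separate the effect of the oxygen link from that of the larger group. On these data alone, how a smaller ether such as methoxy, or a primary amine, would read at this place remains open.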